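The source may report more compounds than this note shows. Statements on the series, on what has been measured and on what is new or still open speak of the compounds shown alone.

Three compounds share one core and differ only in the aryl group attached to it. Compound 1 `Cc1nc2c3ccccc3ccc2c2nc3c(ccc4ccccc43)c(-c3cccc([N+](=O)[O-])c3)c12` gives 117 ug/mL in a functional assay, read by spectrophotometry, with a stated time of 30 min; a higher number here means a weaker inhibitor, a lower number a stronger inhibitor. Compound 2 `Cc1nc2c3ccccc3ccc2c2nc3c(ccc4ccccc43)c(-c3ccccc3Cl)c12` gives 118 ug/mL. Compound 3 `Cc1nc2c3ccccc3ccc2c2nc3c(ccc4ccccc43)c(-c3ccc(O)cc3)c12` gives 86.4 ug/mL. On these numbers compound 3 stands alongside the other two rather than apart from them: the steps of a 1.4-fold lower number from compound 1 to compound 3 (0.13 log units; within the scatter) and a 1.4-fold lower number from compound 2 to compound 3 (0.14 log units; within the scatter) both fall within the scatter, as does a 1.0-fold higher number from compound 1 to compound 2 (0.00 log units; within the scatter). Compound 4 `Cc1nc2c3ccccc3ccc2c2nc3c(ccc4ccccc43)c(-c3cc(O)nc4ccccc34)c12` carries the change (2-hydroxyquinolin-4-yl in place of 4-hydroxyphenyl on an aromatic carbon). Every measured exchange of this aryl group so far left the number unchanged beyond the scatter, so the expected step of a 1.0-fold lower number from compound 3 to compound 4 (0.01 log units; within the scatter) is likewise one with no clear direction. Compound 4 is therefore estimated to give about 85 ug/mL, with a likely range from 40 ug/mL to 180 ug/mL.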

Compound 4, half-maximal inhibitory concentration: 92.1 ug/mL
Estimate against measurement, compound 4: 1.1-fold (0.03 log units) below; the range from low to high includes it.
By their numbers in this assay, from the lowest: compounds 3, 4, 1 and 2 (each within the scatter of the next).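

The position also accepts 2-hydroxyquinolin-4-yl, which brings a second aromatic ring, one holding a nitrogen, without a clear shift in this assay: the steps of a 1.1-fold higher number from compound 3 to compound 4 (0.03 log units; within the scatter), a 1.3-fold lower number from compound 2 to compound 4 (0.11 log units; within the scatter) and a 1.3-fold lower number from compound 1 to compound 4 (0.10 log units; within the scatter) all stay within the scatter. Across these four compounds, then, one aromatic ring or two at this place give numbers that cannot be told apart. Nothing available explains this flat result.

Going by these compounds, all four groups are aromatic, so it remains open whether an amine, a carboxylic acid or a longer alkyl chain here would move the number beyond the scatter.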